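Replacing a 3-nitrophenyl group on a shared core

The source may report more compounds than this note shows. Statements on the series, on what has been measured and on what is new or still open speak of the compounds shown alone.

In a functional assay on SMMC-7721 cells (Homo sapiens) for cytotoxicity, read by MTT assay, with a stated time of 24 h (a higher number here means a weaker inhibitor, a lower number a stronger inhibitor), compound 1 `O=C1/C(=C/c2cccc([N+](=O)[O-])c2)CN(S(=O)(=O)c2ccc(F)cc2)C/C1=C\c1cccc([N+](=O)[O-])c1` gives 3980 nM and compound 2 `O=C1/C(=C/c2cccc([N+](=O)[O-])c2)CN(S(=O)(=O)c2ccc(F)cc2)C/C1=C\c1ccccc1F` gives 7820 nM, so compound 2 stands level with compound 1 within the usual scatter. Compound 3 `COc1cc(/C=C2\CN(S(=O)(=O)c3ccc(F)cc3)C/C(=C\c3ccccc3F)C2=O)cc(OC)c1` differs from compound 2 by one swap: 3,5-dimethoxyphenyl in place of 3-nitrophenyl on a double-bonded chain carbon bound to a double-bonded ring carbon. For the measured compounds named here, the only measured step that also removes a 3-nitrophenyl from this place is a 2.0-fold higher number from compound 1 to compound 2 (0.29 log units; within the scatter), and it stays within the scatter. No 3,5-dimethoxyphenyl compound has been measured yet, so no shift beyond the scatter is expected in this assay. The expected 1.2-fold lower number from compound 2 to compound 3 (0.08 log units; within the scatter) reflects this. Compound 3 is estimated at 6500 nM, with a range of 2500 nM to 16000 nM.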

Compound 3, half-maximal inhibitory concentration: 6890 nM
Compound 3: middle estimate off by 1.1-fold (0.03 log units), on the low side; low and high end bracket the measured number.
By their numbers in this assay, from the lowest: compounds 1, 3 and 2 (each within the scatter of the next).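

In this assay the swap gives a 1.1-fold lower number from compound 2 to compound 3 (0.05 log units; within the scatter) and shows that a second, different group can replace 3-nitrophenyl at this place without a shift beyond the scatter. Here a group containing nitrogen gives way to one with only carbon and oxygen outside its hydrogens, and the number still holds within the scatter. No measurement available here explains why.

No change at this place has yet moved the number beyond the scatter. From the compounds shown here alone, whether an amine or a carboxylic acid on the phenyl ring would do so remains open.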